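This account rests on a few compounds, and the source may have more. Where it says the series, first, only, none or still open, it means among the compounds named here.

Measured compounds:
- compound 1 `Cc1n[nH]c2ccc(-c3nc4cnc(N5CCN(C)CC5)cn4c3Nc3ccccc3F)cc12`: "not determined" (no result reported)
- compound 2 `Cc1n[nH]c2ccc(-c3nc4cnc(N5CCN(C)CC5)cn4c3Nc3ccccc3)cc12`: "not determined" (no result reported)
- compound 3 `Cc1n[nH]c2ccc(-c3nc4cnc(N5CCN(C)CC5)cn4c3Nc3ccc(Br)cc3Cl)cc12`: 9220 nM

All three compounds share one core and differ only in the ring attached to the nitrogen on that core. In a functional assay on MV4-11 cells (Homo sapiens) for inhibition, with a stated time of 120 h (on this read-out higher numbers stand for weaker inhibition and lower numbers for stronger inhibition), compound 1 has no reported number, and compound 2 likewise has none. Going by the values given here, compound 3 is therefore the only compound with a measured value, and in this assay compound 3 gives 9220 nM, a weak inhibition on this read-out, with nothing else to rank it against.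

Compound 4 `Cc1n[nH]c2ccc(-c3nc4cnc(N5CCN(C)CC5)cn4c3Nc3ccc(F)cc3Br)cc12` is the next step. It carries 2-bromo-4-fluorophenyl in place of 4-bromo-2-chlorophenyl on a nitrogen on an aromatic ring. The two halogens are kept in number but exchanged in kind and in place, so that the ring still holds one bromine, while the chlorine gives way to a fluorine. No measured pair among these compounds shows what such an exchange does, so there is no step to lean on.

On that basis the expectation is a change from compound 3 to compound 4 of a 1.0-fold lower number from compound 3 to compound 4 (0.01 log units; within the scatter), that is, nothing clearly beyond the scatter in either direction. Compound 4 is thus estimated at 9000 nM in this assay, within a range from 3000 nM to 30000 nM.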

Compound 4, half-maximal inhibitory concentration: 3830 nM
The estimate for compound 4 lay 2.3-fold (0.37 log units) above the measured number; the measured number falls inside the stated range.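

In this assay, the exchange of halogens on this ring gives a 2.4-fold lower number from compound 3 to compound 4 (0.38 log units; beyond the scatter), the first readable sign that the number responds to a change at this position. The two groups match in everything counted here, with the same number of heavy atoms, no hydrogen-bond donors or acceptors and no net charge, so the shift comes with a change in the kind and place of the halogens alone; yet chlorine leaves, fluorine enters and bromine changes place all in one step, and this single pair cannot separate those three changes. No measurement shown here explains the shift.

On these data alone, compounds 1 and 2 carry no numbers, so any steps to them cannot be read, and the effect of removing the halogens, wholly or in part, stays unknown. Also open, as far as these compounds go, is whether a methoxy group or a nitrile on this ring, in place of the halogens, can give clearly stronger inhibition than compound 4, which stands at 3830 nM.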